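Triazole aryl swap: from compound 2 to compound 3

This account rests on a few compounds, and the source may have more. Where it says the series, first, only, none or still open, it means among the compounds named here.

Measured so far in an ADME assay on HeLa cells (Homo sapiens) for cytotoxicity, read by MTT assay; on this read-out higher numbers stand for weaker inhibition and lower numbers for stronger inhibition:
- compound 1 `COc1ccc(C[C@H]2COC(=O)[C@@H]2Cc2ccc(OCc3cn(Cc4ccc(Cl)cc4)nn3)c(OC)c2)cc1OC` gives 242000 nM
- compound 2 `COc1ccc(C[C@H]2COC(=O)[C@@H]2Cc2ccc(OCc3cn(-c4ccc(C)cc4)nn3)c(OC)c2)cc1OC` gives >= 600000 nM (a limit)

Compound 2 stands at >= 600000 nM in this assay, and this is a limit of the assay, not a number.

The next compound is compound 3 `COc1ccc(C[C@H]2COC(=O)[C@@H]2Cc2ccc(OCc3cn(-c4cccc(Cl)c4)nn3)c(OC)c2)cc1OC`, with 3-chlorophenyl in place of 4-methylphenyl on an aromatic nitrogen.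

Among the measured compounds shown here, one measured step bears on this change: an at least 2.4-fold higher number from compound 1 to compound 2 (0.39 log units; beyond the scatter), with 4-methylphenyl in place of 4-chlorobenzyl on an aromatic nitrogen. For the measured compounds named here, it bears only in part, as no measured compound yet carries 3-chlorophenyl, and its size is known only as a minimum.

A modest step towards a lower number is therefore expected, though a reading at the limit remains quite possible. Compound 1 (242000 nM) marks the low side of this expectation. The estimated change is an at least 1.4-fold lower number from compound 2 to compound 3 (0.15 log units; that floor lies within the scatter) in this assay for now. For compound 3 the estimate is 420000 nM with an expected range from 200000 nM to 600000 nM as its bounds.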

Compound 3, half-maximal inhibitory concentration: 493000 nM
For compound 3 the middle estimate is 1.2-fold (0.07 log units) below the measured one; the range from low to high includes it.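

In this assay, compound 3 puts a number rather than a limit on a phenyl group carried directly on the aromatic nitrogen, and the 3-chlorophenyl swap reads as an at least 1.2-fold lower number from compound 2 to compound 3 (0.08 log units; that floor lies within the scatter). Set against 4-chlorobenzyl, 3-chlorophenyl gives a 2.0-fold higher number from compound 1 to compound 3 (0.31 log units; beyond the scatter), so the two compounds with a phenyl group on that nitrogen, compound 2 and compound 3, both lie on the high side of compound 1, and this shift now has a measured size rather than only a minimum. How far 3-chlorophenyl and 4-methylphenyl lie apart cannot be told, because the step between them has only a floor: the limit of >= 600000 nM in this assay, at which 1 of the 3 values shown sits.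

The compounds shown leave open whether the shift from compound 1 follows the shorter link to the ring or the change in ring substitution, and a 4-chlorophenyl or 3-chlorobenzyl group on the same nitrogen would separate the two. Also open, going by these compounds, is how an amine or a carboxylic acid on that phenyl ring would read in this assay.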